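The source may hold more compounds than are shown below. What is called first, only, known or untested is meant among the compounds shown, and "the series" means these compounds.

Measured so far in a functional assay on the whole organism for antagonist activity, with Mus musculus as the target; a higher number here means that more compound is needed for the effect, a lower number that less compound is needed:
- compound 1 `CN(C)CC#CCN1CCNC1=O`: > 100 mg/kg
- compound 2 `CN1CCN(CC#CCn2ccnc2)C1=O`: > 100 mg/kg

Neither entry is a number, and each is a limit of the assay. Compound 2 stands at the limit > 100 mg/kg in this assay, so no exact position can be given for it. Its reading is not alone, as the measured set offers only (the limit of > 100 mg/kg in this assay, at which 2 of the 2 values shown sit).

The next compound, compound 3 `CN(C)CC#CCN1CCN(C)C1=O`, differs from compound 2 in one place: dimethylamino in place of 1H-imidazol-1-yl on a saturated chain carbon bound to a triple-bonded carbon. In words, this is dimethylamino in place of 1H-imidazol-1-yl on a saturated chain carbon bound to a triple-bonded carbon.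

Among the measured compounds shown here, no measured step shows what such a change does in this assay, and two limits give no size or direction to build on. The expectation is therefore modest: no step beyond the usual scatter, and quite possibly another limit rather than a number. The expected change is a number no higher from compound 2 to compound 3 (the limit leaves the size open). For compound 3 the estimated value is 100 mg/kg, with an expected range of 30 mg/kg to 300 mg/kg.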

Compound 3, dose for half-maximal effect: > 10 mg/kg
Compound 3 ended at the assay's limit; the forecaster's own chance of this, stated with the estimate: 65%; the middle value is on the limit's open side.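

In this assay compound 3 gives > 10 mg/kg, which is a limit of the assay and not a number. The steps from compound 1 and from compound 2 to compound 3 run from limit to limit and cannot be read. The compounds shown leave open whether either change alters the dose needed at all.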